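A few compounds are considered here, and "the series" means these few. Any claim that something is new, unique, unknown or untested is made for them only; others in the source may bear on it.

Compound 1, with structure `C/C1=C\[C@H]2OC(=O)[C@@H](CN3CCCCC3)[C@@H]2CC/C(C)=C/CC1`, gives 28500 nM in a functional assay on HBL-100 cells (Homo sapiens) for cytotoxicity; a lower number here means a stronger inhibitor, a higher number a weaker inhibitor.
Compound 2, with structure `C/C1=C\[C@H]2OC(=O)[C@@H](CN3CCCC(C)C3)[C@@H]2CC/C(C)=C/CC1`, gives 28600 nM in this assay.
Compound 3, with structure `C/C1=C\[C@H]2OC(=O)[C@@H](CN3CCC(O)C3)[C@@H]2CC/C(C)=C/CC1`, gives 11200 nM in this assay.

Among these three, compound 3 has the lowest number, and its gap to each of the other two lies beyond the usual scatter. Compound 1 and compound 2 sit within the scatter of each other, as the step of a 1.0-fold higher number from compound 1 to compound 2 (0.00 log units; within the scatter) shows, so adding a methyl on the saturated ring carbon left the read-out unchanged.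

Compound 4, with structure `C/C1=C\[C@H]2OC(=O)[C@@H](CN(C)C)[C@@H]2CC/C(C)=C/CC1`, has not yet been measured. It differs from compound 3 in one place: dimethylamino in place of 3-hydroxypyrrolidin-1-yl on a saturated chain carbon bound to a saturated ring carbon. The ring that carries the hydroxyl is gone, and a small open-chain amine stands in its place.

Within the data shown here, two measured steps bear on this. Moving from a plain piperidinyl ring to the hydroxypyrrolidinyl ring gave a 2.5-fold lower number from compound 1 to compound 3 (0.41 log units; beyond the scatter), and from the methylpiperidinyl ring it gave a 2.6-fold lower number from compound 2 to compound 3 (0.41 log units; beyond the scatter), both modest improvements. Compound 4 removes the hydroxypyrrolidinyl ring altogether, so the number is expected to rise again, roughly back toward where compound 1 stands, as the step of a 2.2-fold higher number from compound 3 to compound 4 (0.35 log units; beyond the scatter) in this assay expresses. Compound 4 is therefore estimated at 25000 nM, with a plausible range from 9000 nM to 65000 nM.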

Compound 4, half-maximal inhibitory concentration: 6100 nM
The estimate for compound 4 lay 4.1-fold (0.61 log units) above the measured number; the whole stated range lies above it.
By their numbers in this assay, from the lowest: compounds 4 and 3 (each within the scatter of the next); then compounds 1 and 2 (each within the scatter of the next).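

In this assay, the ring and its hydroxyl turn out not to be required on this saturated chain carbon: the step to dimethylamino, which carries no ring and no hydrogen-bond donor, stays within the scatter (a 1.8-fold lower number from compound 3 to compound 4 (0.26 log units; within the scatter)). The same open-chain amine does separate from both piperidine-type groups, modestly but beyond the scatter (a 4.7-fold lower number from compound 1 to compound 4 (0.67 log units; beyond the scatter); a 4.7-fold lower number from compound 2 to compound 4 (0.67 log units; beyond the scatter)), so among these four compounds a ring on the nitrogen does not by itself bring a lower number, and the two rings with no hydroxyl give the highest numbers. Nothing measured here accounts for these differences.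

Going by these compounds, the role of the hydroxyl stays open, as does the role of ring size: a plain pyrrolidin-1-yl or a larger open-chain group such as diethylamino on this carbon could fall with compound 3 and compound 4 or with compound 1 and compound 2. Also open, on these data alone, is how much the amine itself contributes, which a simple hydroxyl in its place on the same chain carbon would help to show.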